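Ester for ketone on the aldehyde-bearing core

The source may report more compounds than this note shows. Statements on the series, on what has been measured and on what is new or still open speak of the compounds shown alone.

Measured so far:
- compound 1, `CCC(C)c1cc(/C=C/C(=O)c2ccc(Cl)cc2)cc2cc(C(C)=O)c(=O)oc12`: in a functional assay on KB cells (Homo sapiens) for cytotoxicity, read by sulforhodamine B assay, with a stated time of 48 h (on this read-out higher numbers stand for weaker inhibition and lower numbers for stronger inhibition), compound 1 is reported as "not active" (no number reported)
- compound 2, `CCOC(=O)c1cc2cc(/C=C/C(=O)c3ccc(C)cc3)cc(C(C)CC)c2oc1=O`: in this assay compound 2 gives 18000 nM
- compound 3, `CCC(C)c1cc(C=O)cc2cc(C(C)=O)c(=O)oc12`: in this assay compound 3 gives 176000 nM

Compound 3 carries the highest of the two numbers reported, that is, the weakest inhibition among the compounds with a number. Going by the values given here, the gap to compound 2 lies beyond the usual scatter, but compound 2 differs from compound 3 in more than one place, so the two values show only that the aldehyde-bearing compound with an acetyl group sits well above the enone-bearing ester. Compound 1, with the enone and the acetyl group, has no number at all.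

Compound 4, `CCC(C)c1cc(C=O)cc2cc(C(=O)OC)c(=O)oc12`, differs from compound 3 in a single place: methoxy in place of methyl on a carbonyl carbon. Among the compounds with values here, no pair of measured compounds isolates this change, so nothing in the data fixes its size. The step from compound 3 to compound 4 in this assay is expected to be small, a 1.2-fold lower number from compound 3 to compound 4 (0.07 log units; within the scatter), with no clear direction beyond the scatter.

For compound 4 the estimate in this assay is 150000 nM, with a range of 50000 nM to 450000 nM.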

Compound 4, half-maximal inhibitory concentration: 146000 nM
Estimate against measurement, compound 4: 1.0-fold (0.01 log units) above, and the stated range covers the measured number.
By their numbers in this assay, from the lowest: compound 2; then compounds 4 and 3 (each within the scatter of the next).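

Going by these compounds alone, on the aldehyde-bearing core, acetyl to methoxycarbonyl gives a 1.2-fold lower number from compound 3 to compound 4 (0.08 log units; within the scatter) in this assay, so this is the first change that can be read on its own, and the two compounds cannot be told apart. For this one pair, methoxy in place of methyl on a carbonyl carbon therefore leaves no readable step, and the gap seen earlier between compound 3 and compound 2 cannot be assigned to the ester, since compound 2 also carries the enone. No measurement available here offers an explanation for the result beyond the numbers themselves.

On these data alone, whether the same exchange stays within the scatter on the enone-bearing compounds remains open, since compound 1 is reported as "not active" (no number reported) and differs from compound 2 in more than one place, so that step cannot be read. Also open, as far as these compounds go, is how this assay responds when the carbonyl carbon instead carries a hydroxyl group, as in a carboxylic acid, or an amine, as in a primary amide. The compounds shown hold only methyl, methoxy and ethoxy there.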